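Adding 4-methylphenyl to compound 1

This account rests on a few compounds, and the source may have more. Where it says the series, first, only, none or still open, it means among the compounds named here.

For the measured compounds named here, in an ADME assay on J774.A1 cells (Mus musculus) for inhibition, read by MTT assay, with a stated time of 72 h (a lower number here means that less compound is needed, a higher number that more compound is needed for the effect), compound 1 (`CNc1nc(NCc2ccccc2)nc2ccccc12`) gives 15000 nM and compound 2 (`CC(C)Nc1nc(NCc2ccco2)c2ccccc2n1`) gives 17000 nM so the two stand within the scatter of each other, and compound 1 holds no clear place above or below its only measured neighbour. Compound 3 (`Cc1ccc(CNc2nc(NCc3ccccc3)nc3ccccc23)cc1`) follows from compound 1 with 4-methylphenyl in place of hydrogen on a saturated chain carbon bound to a nitrogen on an aromatic ring, which turns methylamino into (4-methylbenzyl)amino. Going by the values given here, no measured pair differing in one place offers a guide, so the expectation rests on the structural change alone. A moderate move towards a lower number in this assay is expected, beyond the scatter but uncertain in size. The expected step is a 2.5-fold lower number from compound 1 to compound 3 (0.40 log units; beyond the scatter) and it remains a rough estimate. The estimated value for compound 3 is 6000 nM (expected range 2000 nM to 18000 nM).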

Compound 3, half-maximal effective concentration: 2100 nM
Compound 3: middle estimate off by 2.9-fold (0.46 log units), on the high side, within the range that was stated.
By their numbers in this assay, from the lowest: compound 3; then compounds 1 and 2 (each within the scatter of the next).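

In this assay, the saturated chain carbon bound to a nitrogen on an aromatic ring proves to be a place where one change moves the number: turning methylamino into (4-methylbenzyl)amino gives a 7.1-fold lower number from compound 1 to compound 3 (0.85 log units; beyond the scatter). For the compounds shown here, the earlier compounds offered no step at any single place, so this is the first reading of how one change acts on this series, and it covers one group at one position. Nothing available explains why the number falls with this change.

As far as these compounds go, whether the fall depends on the 4-methyl group, on the aromatic ring itself or on chain length alone stays open, and a plain benzyl, a 4-chlorobenzyl or a simple butyl group at this place would separate these readings. Also open, from the compounds shown here alone, is how an amine or a carboxylic acid on that ring would change the number.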